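Two aromatic rings swapped on a purine-type scaffold

A few compounds are considered here, and "the series" means these few. Any claim that something is new, unique, unknown or untested is made for them only; others in the source may bear on it.

Compound 1 `NC1CCC(Nc2nc(NCc3ccc(Br)cc3)c3ncn(C4CCCC4)c3n2)CC1` gives 995 nM
Compound 2 `COc1ccccc1-c1ccc(CNc2nc(NC3CCC(N)CC3)nc3c2ncn3C2CCCC2)cc1` gives 150 nM
Compound 3 `NC1CCC(Nc2nc(NCc3ccc(-c4ccsc4)cc3)c3ncn(C4CCCC4)c3n2)CC1` gives 120 nM

All three numbers come from a functional assay on HOS cells (Homo sapiens) for inhibition, with a stated time of 72 h; a higher number here means a weaker inhibitor, a lower number a stronger inhibitor. Among the measured compounds shown here, compound 3 sits at the low end of these numbers, and no measured compound is clearly lower. Exchanging its thiophen-3-yl for 2-methoxyphenyl shows how little separates the two, as a 1.3-fold lower number from compound 2 to compound 3 (0.10 log units; within the scatter) is within the scatter. Replacing bromo with an aromatic ring mattered more, giving a 6.6-fold lower number from compound 1 to compound 2 (0.82 log units; beyond the scatter) and an 8.3-fold lower number from compound 1 to compound 3 (0.92 log units; beyond the scatter), both beyond the scatter.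

Compound 4 `NC1CCC(Nc2nc(NCc3ccc(-c4ccccc4)nc3)c3ncn(C4CCCC4)c3n2)CC1` brings a new change: 6-phenylpyridin-3-yl in place of 4-(thiophen-3-yl)phenyl on a saturated chain carbon bound to a nitrogen on an aromatic ring. For the measured compounds named here, it keeps two linked aromatic rings, and the one measured exchange of the outer ring, a 1.3-fold lower number from compound 2 to compound 3 (0.10 log units; within the scatter), stayed within the scatter. However, no measured compound carries the 6-phenylpyridin-3-yl group, so that part of the change is untested and the range must stay wide. The estimated change is a 1.5-fold higher number from compound 3 to compound 4 (0.18 log units; within the scatter), a step expected to stay within the scatter, if slightly upward. For compound 4 the estimated value is 180 nM, with an expected range from 60 nM to 550 nM.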

Compound 4, half-maximal inhibitory concentration: 206 nM
Compound 4: middle estimate off by 1.1-fold (0.06 log units), on the low side, within the range that was stated.
By their numbers in this assay, from the lowest: compounds 3, 2 and 4 (each within the scatter of the next); then compound 1.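

Replacing the ring attached to the chain carbon is tolerated as well: the earlier exchange touched only the outer ring, whereas 6-phenylpyridin-3-yl also brings a ring with a nitrogen into that inner place, and this assay shows a 1.7-fold higher number from compound 3 to compound 4 (0.23 log units; within the scatter) for this change. The advantage over the bromo compound also survives this change, with a 4.8-fold lower number from compound 1 to compound 4 (0.68 log units; beyond the scatter) as the step from a single bromo atom on the benzene ring to this two-ring group, so three different two-ring groups now stand clearly below compound 1. The data offer no explanation for either step.

As far as these compounds go, whether a second aromatic ring is needed at all remains open, and a morpholine or a simple amine in its place would test this. Also open, from the compounds shown here alone, is how a carboxylic acid on the outer phenyl ring would fare.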